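A few compounds are considered here, and "the series" means these few. Any claim that something is new, unique, unknown or untested is made for them only; others in the source may bear on it.

Measured compounds:
compound 1 `CCn1c(C(=O)N(CCC#N)CCC#N)ccc1C(CC)(CC)c1ccc(OCCC(O)(CC)CC)c(C)c1` – > 50000 nM
compound 2 `CCn1c(C(=O)Nc2ccc(OC(F)(F)F)cc2)ccc1C(CC)(CC)c1ccc(OCCC(O)(CC)CC)c(C)c1` – > 50000 nM

In a functional assay on MCF7 cells (Homo sapiens) for antiproliferative activity, read by MTT assay, with a stated time of 48 h (a higher number here means a weaker inhibitor, a lower number a stronger inhibitor), compound 1 gives only a limit of the assay, > 50000 nM. Compound 2 likewise gives only a limit, > 50000 nM. The step that the two limits leave unreadable from compound 1 to compound 2 therefore has no readable size, as the limit of > 50000 nM in this assay, at which 2 of the 2 values shown sit, shows. Among the measured compounds shown here, compound 2 thus stands at that limit, together with the one other value. Compound 3 `CCOC(=O)CN(C)C(=O)c1ccc(C(CC)(CC)c2ccc(OCCC(O)(CC)CC)c(C)c2)n1CC` differs from compound 2 by ((ethoxycarbonyl)methyl)(methyl)amino in place of (4-(trifluoromethoxy)phenyl)amino on a carbonyl carbon. For the measured compounds named here, no measured step with a readable size bears on this change, so no direction can be drawn from the data. Compound 3 is expected to remain at the limit as well, estimated at 50000 nM within 20000 nM to 120000 nM. The expected step is a number no higher from compound 2 to compound 3 (the limit leaves the size open).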

Compound 3, half-maximal inhibitory concentration: 3210 nM
Compound 3: the middle estimate sits 16-fold (1.19 log units) above what was measured; measured number below the stated range.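

On a carbonyl carbon, ((ethoxycarbonyl)methyl)(methyl)amino in place of (4-(trifluoromethoxy)phenyl)amino gives an at least 15-fold lower number from compound 2 to compound 3 (1.19 log units; beyond the scatter) in this assay, so this position can change the read-out, which the unreadable step from compound 1 to compound 2 could not show. The same group, replacing the group of compound 1, gives an at least 15-fold lower number from compound 1 to compound 3 (1.19 log units; beyond the scatter). Both steps start from a limit, so their full size is unknown: the limit of > 50000 nM in this assay, at which 2 of the 3 values shown sit.

Which part of the entering group carries the change stays open. So does whether a carboxylic acid in place of the ethoxycarbonyl group, or a simple dimethylamino group, would give a similar value.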